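Adding one methyl to compound 2

The source may report more compounds than this note shows. Statements on the series, on what has been measured and on what is new or still open speak of the compounds shown alone.

Compound 2 `CCOC(=O)N(C)C(C)C#CCn1ccnc1` gives > 100 mg/kg in a functional assay on the whole organism for agonist activity, with Mus musculus as the target (on this read-out higher numbers stand for an effect only at larger amounts of compound and lower numbers for an effect already at smaller amounts), and this is a limit of the assay, not a number. Compound 3 `CCOC(=O)N(C)C(C)C#CCn1cncc1C` differs from it by methyl in place of hydrogen on an aromatic carbon and so carries 5-methyl-1H-imidazol-1-yl instead of 1H-imidazol-1-yl. Among the measured compounds shown here, compound 1 `COC(=O)N(C)C(C)C#CCn1cncc1C` also carries 5-methyl-1H-imidazol-1-yl and gives 97 mg/kg in this assay as the only guide. Going by compound 1 at 97 mg/kg only a small move toward smaller doses is expected. The estimated at least 1.1-fold lower number from compound 2 to compound 3 (0.07 log units; that floor lies within the scatter) may stay within the usual scatter. For compound 3 the estimated value is 85 mg/kg with 35 mg/kg to 200 mg/kg as its expected range.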

Compound 3, dose for half-maximal effect: > 100 mg/kg
Compound 3 was reported as a limit (the forecaster's own chance of this, stated with the estimate: 35%); middle value at least 1.1-fold (0.07 log units) away from the limit.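

The step from hydrogen to methyl on this aromatic carbon cannot be read, because compound 2 and compound 3 both stop at the same point: the limit of > 100 mg/kg in this assay, at which 2 of the 3 values shown sit.

In this assay compound 3 gives > 100 mg/kg, which is a limit and not a number. Among the compounds shown here, the one readable step, for methyl in place of hydrogen on a saturated chain carbon bound to an oxygen next to a carbonyl group, is an at least 1.0-fold higher number from compound 1 to compound 3 (0.01 log units; that floor lies within the scatter), so its true size remains unknown.

Going by these compounds, whether the ring methyl changes the dose at all stays open. So does how a longer chain or an amine on this aromatic carbon would read in this assay.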